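A few compounds are considered here, and "the series" means these few. Any claim that something is new, unique, unknown or untested is made for them only; others in the source may bear on it.

In a functional assay on U-373MG ATCC cells for cytotoxicity against U373 MG (Homo sapiens), read by colorimetric assay and MTT assay (a higher number here means a weaker inhibitor, a lower number a stronger inhibitor), compound 1 (`COc1cccc2cc(-c3ccccc3)c(O)nc12`) reads 10000 nM and compound 2 (`COc1cc(OC)c2cc(-c3ccc(OCc4ccccc4)cc3)c(O)nc2c1`) reads 10000 nM as well. Compound 3 (`CCOC(=O)Cn1c(=O)c(-c2ccc(OC)cc2)cc2c(OC)cc(OC)cc21`) gives 10000 nM in the same measurement, which places it level with compound 1 and compound 2. Among the measured compounds shown here, the three compounds differ from one another in more than one place, so no measured pair isolates a single structural change.

The next compound to be read is compound 4 (`COc1ccc(-c2cc3c(OC)cc(OC)cc3n(CC(=O)O)c2=O)cc1`). It departs from compound 3 in one place (hydrogen in place of ethyl on an oxygen next to a carbonyl group), with hydrogen in place of ethyl on an oxygen next to a carbonyl group. The same difference, seen one bond further out, turns (ethoxycarbonyl)methyl into carboxymethyl. For the measured compounds named here, nothing measured so far shows what this exchange does in this assay and the only guide is the flat set of readings. Starting from compound 3 at 10000 nM the expectation is for no step beyond the scatter and for no particular direction. The estimated change is no change at the digits printed from compound 3 to compound 4 (within the scatter) and it is expected to stay within that scatter. The estimate for compound 4 is 10000 nM with an expected range from 5000 nM to 20000 nM once it has been measured.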

Compound 4, half-maximal inhibitory concentration: 10000 nM
Estimate against measurement, compound 4: no gap at the digits printed; measured number inside the range.
By their numbers in this assay, from the lowest: compounds 1, 2, 3 and 4 (each within the scatter of the next).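

Among the compounds shown here, the exchange of ethyl for hydrogen on an oxygen next to a carbonyl group gives the first comparison in this assay that isolates a single structural change, and it shows no change at the digits printed from compound 3 to compound 4 (within the scatter) in this pair. For the compounds shown here, at this position, then, (ethoxycarbonyl)methyl and carboxymethyl cannot be told apart by this read-out, something the earlier compounds could not show, as they differ from one another in more than one place. No measurement at hand offers an explanation for this result.

Going by these compounds alone, with all four compounds level, the single step says nothing about whether any group at this position could move the reading, or whether the same exchange would read alike on a core carrying a different set of other substituents. An amide such as carbamoylmethyl, an amine such as 2-aminoethyl, or a longer chain such as 3-carboxypropyl at this position remains an open case, and so does any change elsewhere on the shared core.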